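Cyclohexylbenzimidazole imidazopyrazines: thiophene for acetylphenyl at the aryl position

This account rests on a few compounds, and the source may have more. Where it says the series, first, only, none or still open, it means among the compounds named here.

Three members of the series have numbers in a functional assay on SK-MEL-5 cells (Homo sapiens) for inhibition, read by sulforhodamine B assay, with a stated time of 48 h, tested at 10 uM; on this read-out higher numbers stand for more inhibition at the one concentration tested (going by the name of the read-out) and lower numbers for less inhibition. Compound 1 `c1ccc2c(-c3cn4ccnc4c(-c4ccc5ncn(C6CCCCC6)c5c4)n3)cccc2c1` gives 4.06%, compound 2 `Fc1ccc(-c2cn3ccnc3c(-c3ccc4ncn(C5CCCCC5)c4c3)n2)cc1` gives 7.36%, and compound 3 `CC(=O)c1ccc(-c2cn3ccnc3c(-c3ccc4ncn(C5CCCCC5)c4c3)n2)cc1` gives 24.8%. Compound 3 stands highest of the three: the nearest is compound 2, with a number 17.4 percentage points higher from compound 2 to compound 3 (beyond the scatter), and the furthest is compound 1, with a number 20.7 percentage points higher from compound 1 to compound 3 (beyond the scatter), both beyond the scatter. The two lower compounds lie within the scatter of each other, a number 3.3 percentage points higher from compound 1 to compound 2 (within the scatter).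

Compound 4 `c1csc(-c2cn3ccnc3c(-c3ccc4ncn(C5CCCCC5)c4c3)n2)c1` differs from compound 3 in one place: thiophen-2-yl in place of 4-acetylphenyl on an aromatic carbon. For the measured compounds named here, the steps that bear on it are those in which the acetyl-bearing aryl gave way to another aryl. Read in reverse, two steps of modest size, a number 17.4 percentage points higher from compound 2 to compound 3 (beyond the scatter) and a number 20.7 percentage points higher from compound 1 to compound 3 (beyond the scatter), show what replacing the acetyl-bearing aryl has done. Compound 4 carries no carbonyl, so a step downward of similar size is expected, a number 14.8 percentage points lower from compound 3 to compound 4 (beyond the scatter). For compound 4 in this assay the estimate is 10%, with a range from 0% to 25%.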

Compound 4, a percentage reported as inhibition, at one concentration (the size of the read-out at that concentration, not a potency): 8.05%
Estimate against measurement, compound 4: 2 percentage points above; the measured number falls inside the stated range.
By their numbers in this assay, from the lowest: compounds 1, 2 and 4 (each within the scatter of the next); then compound 3.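

In this assay, thiophen-2-yl at this position does not keep the level of the 4-acetylphenyl group (a number 16.8 percentage points lower from compound 3 to compound 4 (beyond the scatter)). It falls in with the 4-fluorophenyl and naphthalen-1-yl groups instead (a number 0.7 percentage points higher from compound 2 to compound 4 (within the scatter); a number 4 percentage points higher from compound 1 to compound 4 (within the scatter)), so a five-membered ring with sulfur and two carbon-only aromatic groups give values within the scatter of one another, and among these four compounds only compound 3 stands apart. Nothing at hand accounts for this separation.

Going by these compounds, whether the higher number follows the carbonyl or the whole 4-acetylphenyl group remains open, and a phenyl ring carrying an amide, a carboxylic acid or an amine in place of the acetyl would test this. A read-out at a single concentration also gives no potency for any of the four compounds.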